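Swapping the aryl on the triazole of a spirooxindole

The compounds below may be only part of what the source reports. "The series", "measured", "known", "first", "only" and "open" are said of these compounds alone.

Compound 1 `N#CC1=C(N)Oc2c(N)cc3nc4ccccc4nc3c2C12C(=O)N(Cc1cnnn1-c1ccc(F)cc1)c1ccccc12` gives a limit of > 50000 nM in a functional assay on MCF7 cells (Homo sapiens) for antiproliferative activity, read by MTT assay, with a stated time of 48 h; on this read-out higher numbers stand for weaker inhibition and lower numbers for stronger inhibition; this is a limit, not a number.
Compound 2 `COc1ccc(OC)c(-n2nncc2CN2C(=O)C3(C(C#N)=C(N)Oc4c(N)cc5nc6ccccc6nc5c43)c3ccccc32)c1` gives 28100 nM in this assay.

Among the measured compounds shown here, compound 2 holds the only number measured in this assay; the other value is the limit (the limit of > 50000 nM in this assay, at which 1 of the 2 values shown sits). For the measured compounds named here, the step of an at least 1.7-fold lower number from compound 1 to compound 2 (0.25 log units; that floor lies within the scatter) is the one measured step, and it rests on that limit. Compound 3 `Cc1cc(C)c(-n2nncc2CN2C(=O)C3(C(C#N)=C(N)Oc4c(N)cc5nc6ccccc6nc5c43)c3ccccc32)c(C)c1` differs from compound 2 by 2,4,6-trimethylphenyl in place of 2,5-dimethoxyphenyl on an aromatic nitrogen. Going by the values given here, no measured step covers this kind of exchange, so the expected step of a 1.1-fold higher number from compound 2 to compound 3 (0.03 log units; within the scatter) is no more than the scatter. Compound 3 is therefore estimated at 30000 nM, between 12000 nM and 80000 nM.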

Compound 3, half-maximal inhibitory concentration: > 50000 nM
Compound 3: only a limit was reported (the forecaster's own chance of this, stated with the estimate: 30%); at least 1.6-fold (0.22 log units) between middle value and limit.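

In this assay compound 3 gives > 50000 nM, which is a limit and not a number. Among the compounds shown here, the 2,4,6-trimethylphenyl group thus joins the 4-fluorophenyl group in giving no measured number, and the one step that can be read, an at least 1.7-fold higher number from compound 2 to compound 3 (0.25 log units; that floor lies within the scatter), rests on this limit. The step that joins compound 1 with compound 3 cannot be read, and most values at this position are now limits: the limit of > 50000 nM in this assay, at which 2 of the 3 values shown sit.

Left open is whether a single methoxy group on the phenyl ring, or an amine or a carboxylic acid in place of the aryl group, would give a number in this assay.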